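A few compounds are considered here, and "the series" means these few. Any claim that something is new, unique, unknown or untested is made for them only; others in the source may bear on it.

Of the compounds shown here, three with the shared core have been measured in a functional assay on HPAC cells (Homo sapiens) for inhibition, read by MTT assay, with a stated time of 72 h; a higher number here means a weaker inhibitor of growth, a lower number a stronger inhibitor of growth. Compound 1 `O=S(=O)(NCCNCc1cccc2ccccc12)c1cc(C(F)(F)F)cc(C(F)(F)F)c1` gives 18000 nM, compound 2 `O=S(=O)(NCCCNCc1ccccc1Cl)c1cc(C(F)(F)F)cc(C(F)(F)F)c1` gives 10000 nM, and compound 3 `O=S(=O)(NCCNCc1ccc(-c2ccccc2)cc1)c1cc(C(F)(F)F)cc(C(F)(F)F)c1` gives 2800 nM. Compound 2 therefore holds the second highest of the three numbers; its value and that of compound 1 lie within the usual scatter of each other, whereas compound 3 sits lower by more than the scatter. Compound 4 `COc1ccc(CNCCCNS(=O)(=O)c2cc(C(F)(F)F)cc(C(F)(F)F)c2)cc1OC` has not yet been measured. It differs from compound 2 in one place: 3,4-dimethoxyphenyl in place of 2-chlorophenyl on a saturated chain carbon bound to an amine nitrogen. Among the measured compounds shown here, no pair of measured compounds shows this same change, so the data give no guide to how a 3,4-dimethoxyphenyl group compares with a 2-chlorophenyl group at the place of the change. The expected step is a 1.2-fold higher number from compound 2 to compound 4 (0.08 log units; within the scatter), which is to say no change beyond the scatter in either direction, with a slight lean toward a weaker result. The estimate for compound 4 in this assay is 12000 nM, with a range from 4000 nM to 40000 nM.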

Compound 4, concentration for 50% growth inhibition: 3500 nM
Estimate against measurement, compound 4: 3.4-fold (0.54 log units) above, outside the stated range (below it).
By their numbers in this assay, from the lowest: compounds 3 and 4 (each within the scatter of the next); then compounds 2 and 1 (each within the scatter of the next).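

In this assay, the group on a saturated chain carbon bound to an amine nitrogen proves able to shift the result: 3,4-dimethoxyphenyl in place of 2-chlorophenyl gives a 2.9-fold lower number from compound 2 to compound 4 (0.46 log units; beyond the scatter), a modest step beyond the scatter. Among the compounds shown here, the earlier compounds differed from one another in more than one place, so this is the first change that can be read on its own. It shows that this position does not tolerate every aromatic group equally, but nothing given here accounts for the step.

Going by these compounds, whether the gain comes from adding the methoxy groups or from removing the chlorine stays open, and an unsubstituted phenyl or a phenyl carrying a single methoxy group could separate the two. Also open, on these data alone, is whether the same change would give a similar step on the shorter chain of compound 3.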